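Swapping Bromo for Iodo on the Shared Core

The compounds below may be only part of what the source reports. "The series", "measured", "known", "first", "only" and "open" are said of these compounds alone.

Two compounds have been measured in an assay on HEK293 cells for displacement of a labelled ligand from P2X purinoceptor 7 (Homo sapiens), read by scintillation counting and radioligand binding, with a stated time of 30 min; on this read-out lower numbers stand for stronger inhibition and higher numbers for weaker inhibition:
compound 1 `CN1C(=O)CC[C@H]1C(=O)NCc1cccc(C(F)(F)F)c1F`: 54.2 nM
compound 2 `CN1C(=O)CC[C@H]1C(=O)NCc1cccc(C(F)(F)F)c1Br`: 2.5 nM

For the measured compounds named here, compound 2 gives the lower of the two numbers; the only measured step, a 22-fold lower number from compound 1 to compound 2 (1.34 log units; beyond the scatter), was large. Compound 3 `CN1C(=O)CC[C@H]1C(=O)NCc1cccc(C(F)(F)F)c1I` differs from compound 2 by iodo in place of bromo on an aromatic carbon. Going by the values given here, that step extends the same halogen series, so the fluoro-to-bromo step is the only guide, and a further, smaller downward move or no change beyond the scatter seems plausible. Compound 3 is therefore expected to give about 1.5 nM, within 0.4 nM to 6 nM, a step of a 1.7-fold lower number from compound 2 to compound 3 (0.22 log units; within the scatter) in this assay.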

Compound 3, inhibition constant: 1.9 nM
For compound 3 the middle estimate is 1.3-fold (0.10 log units) below the measured one, and the stated range covers the measured number.
By their numbers in this assay, from the lowest: compounds 3 and 2 (each within the scatter of the next); then compound 1.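

In this assay the change shows a 1.3-fold lower number from compound 2 to compound 3 (0.12 log units; within the scatter) and so no real separation of iodo from bromo at this position, ortho to a trifluoromethyl group. Iodo keeps the advantage over fluoro that bromo had, with a 29-fold lower number from compound 1 to compound 3 (1.46 log units; beyond the scatter) as the step, so the large drop is not tied to bromo alone. Nothing given here says why this is so.

Going by these compounds, whether chloro would read like bromo or like fluoro stays open. So does how a non-halogen such as methyl or a nitrile would read at this place.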